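The source may report more compounds than this note shows. Statements on the series, on what has been measured and on what is new or still open speak of the compounds shown alone.

Measured so far:
compound 1 `COC(=O)c1ccc(Cc2c3c(n(CC(=O)O)c2C)CCNC3=O)c(S(=O)(=O)c2ccccc2)c1` — 11 nM
compound 2 `COc1cccc(S(=O)(=O)c2ccccc2Cc2c3c(n(CC(=O)O)c2C)CCNC3=O)c1` — 12 nM

The account that follows concerns the step from compound 2 to compound 3. In a functional assay on CHO.K1 cells for antagonist activity at prostaglandin D2 receptor 2 (Homo sapiens), read by GTPgammaS binding, with a stated time of 1 h (a higher number here means a weaker inhibitor, a lower number a stronger inhibitor), compound 2 gives 12 nM, and in the same assay compound 1 gives 11 nM. The two numbers lie within the scatter of one another, so nothing separates compound 2 from compound 1 on this evidence; compound 2 simply carries the higher of the two numbers, and the gap is too small to read as a difference.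

Compound 3 `Cc1c(Cc2ccccc2S(=O)(=O)c2ccc(Cl)cc2)c2c(n1CC(=O)O)CCNC2=O` is not yet measured. It differs from compound 2 in one place only: 4-chlorophenyl in place of 3-methoxyphenyl on a sulfonyl sulfur. For the measured compounds named here, no step between measured compounds of this kind exists, so the expectation rests on the two values alone. Both measured compounds, with unlike groups around the sulfonyl, give numbers within the scatter of each other, which suggests that this region tolerates change. The step from compound 2 to compound 3 is therefore expected to be small, a 1.2-fold lower number from compound 2 to compound 3 (0.08 log units; within the scatter), in no firm direction. Compound 3 is estimated to give 10 nM, with a range from 3 nM to 35 nM.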

Compound 3, half-maximal inhibitory concentration: 8.5 nM
Compound 3: the middle estimate sits 1.2-fold (0.07 log units) above what was measured; measured number inside the range.
By their numbers in this assay, from the lowest: compounds 3, 1 and 2 (each within the scatter of the next).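

In this assay, 4-chlorophenyl in place of 3-methoxyphenyl on a sulfonyl sulfur gives a 1.4-fold lower number from compound 2 to compound 3 (0.15 log units; within the scatter), and this is the only step shown between two measured compounds that differ in one place. Where the two values alone could only hint at tolerance, this step shows directly that one aromatic group on the sulfonyl can replace the other with no difference that this assay can separate, even though the hydrogen-bond acceptor counted on 3-methoxyphenyl is absent from 4-chlorophenyl and a chlorine enters. Nothing measured here offers an explanation for this outcome, so the result stands as an observation about these two groups alone.

The step changes both the substituent and its place on the phenyl ring, so a flat result may reflect either no effect from each change or two effects that offset one another, and the compounds shown cannot tell these apart. They also leave open whether this tolerance extends beyond substituted phenyl groups, for instance to a phenyl ring carrying an amine or a carboxylic acid, or to a short alkyl chain on the sulfonyl sulfur.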